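Replacing iodo with trifluoromethyl on a shared core

This account rests on a few compounds, and the source may have more. Where it says the series, first, only, none or still open, it means among the compounds named here.

Compound 1 `C#C[C@@]1(O)[C@@H](CO)O[C@@H](n2cnc3c(-c4ccccc4)ncnc32)[C@@H]1O`: > 250000 nM (a limit)
Compound 2 `C#C[C@@]1(O)[C@@H](CO)O[C@@H](n2cc(F)c3c(N)ncnc32)[C@@H]1O`: 160 nM
Compound 3 `C#C[C@@]1(O)[C@@H](CO)O[C@@H](n2cc(I)c3c(N)ncnc32)[C@@H]1O`: 120 nM

In a functional assay on CCRF-CEM cells (Homo sapiens) for antiproliferative activity, read by cell counting, with a stated time of 72 h (on this read-out higher numbers stand for weaker inhibition and lower numbers for stronger inhibition), compound 3 gives 120 nM, which lies within the scatter of compound 2 at 160 nM. Compound 1 is reported only as a limit, > 250000 nM. For the measured compounds named here, its core differs from the one shared by the other two compounds, so it offers no measured step for comparison here.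

The next compound to be tested is compound 4 `C#C[C@@]1(O)[C@@H](CO)O[C@@H](n2cc(C(F)(F)F)c3c(N)ncnc32)[C@@H]1O`. It carries trifluoromethyl in place of iodo on an aromatic carbon of a five-membered aromatic ring with 1 nitrogen (trifluoromethyl in place of iodo on an aromatic carbon). Going by the values given here, one measured step bears on this change, as it exchanges the group on the same carbon: a 1.3-fold lower number from compound 2 to compound 3 (0.12 log units; within the scatter). That step, iodo in place of fluoro, lies within the scatter. Among the compounds with values here, no measured compound carries trifluoromethyl, so the guidance is limited. On this evidence, no step beyond the scatter is expected in this assay, with only a slight lean towards a higher number. The expected step is a 1.5-fold higher number from compound 3 to compound 4 (0.18 log units; within the scatter). For compound 4 the estimated value is 180 nM, with an expected range from 60 nM to 1000 nM.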

Compound 4, half-maximal inhibitory concentration: 360 nM
Beside the measured number, compound 4's estimate is 2.0-fold (0.30 log units) below it; low and high end bracket the measured number.
By their numbers in this assay, from the lowest: compounds 3 and 2 (each within the scatter of the next); then compound 4. At a limit, above all of these: compound 1.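

In this assay, the change shows that this aromatic carbon, two ring bonds from the ring nitrogen, is not indifferent to the group it carries: fluoro and iodo had stayed within the scatter of each other, whereas trifluoromethyl gives a 3.0-fold higher number from compound 3 to compound 4 (0.48 log units; beyond the scatter) and also a 2.3-fold higher number from compound 2 to compound 4 (0.35 log units; beyond the scatter) when set against the fluoro compound. Trifluoromethyl is therefore the first group in this small series to move the number beyond the scatter, although both steps are modest and the compound keeps a value in the same nanomolar range as the two halogen compounds. Nothing measured here accounts for this step.

The compounds shown leave open how an amine, a nitrile or a longer alkyl chain on this carbon would behave, and whether any of these would follow trifluoromethyl or stay with the halogens. For the compounds shown here, with only three groups compared at this position, they also leave open whether the heavy-atom count of the entering group has any bearing on the step, since a methyl or an ethyl group would be needed to test this.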